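Cyclopropyl to tert-Butylpyrazole: Expected Microsomal Clearance

The source may report more compounds than this note shows. Statements on the series, on what has been measured and on what is new or still open speak of the compounds shown alone.

Compound 2 `Nc1ccc(S(=O)(=O)N2CCN(c3ncc(C(O)(C(F)(F)F)C(F)(F)F)cc3C3CC3)CC2)cn1` carries a cyclopropyl on an aromatic carbon of the shared core, and in an ADME assay (liver) for metabolic stability, with Liver microsome (Homo sapiens) as the target, using microsomes and NADPH, with a stated time of 30 min, tested at 1 uM (on this read-out lower numbers stand for slow clearance and higher numbers for fast clearance), compound 2 gives 38 mL.min-1.g-1. Among the two numbers reported this is the highest. The nearest is compound 3 `Cn1cc(-c2cc(C(O)(C(F)(F)F)C(F)(F)F)cnc2N2CCN(S(=O)(=O)c3ccc(N)nc3)CC2)cn1`, which in this assay gives 19 mL.min-1.g-1. The gap between them, a 2.0-fold lower number from compound 2 to compound 3 (0.30 log units; within the scatter), lies within the scatter. Compound 1 `COc1cc(C(O)(C(F)(F)F)C(F)(F)F)cnc1N1CCN(S(=O)(=O)c2ccc(N)nc2)CC1` returned only a limit in this assay, < 14 mL.min-1.g-1, so no number is known for it (the limit of < 14 mL.min-1.g-1 in this assay, at which 1 of the 3 values shown sits). Two further steps are recorded: an at least 1.3-fold higher number from compound 1 to compound 3 (0.13 log units; that floor lies within the scatter) and an at least 2.7-fold higher number from compound 1 to compound 2 (0.43 log units; beyond the scatter).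

The unmeasured compound 4 `CC(C)(C)n1cc(-c2cc(C(O)(C(F)(F)F)C(F)(F)F)cnc2N2CCN(S(=O)(=O)c3ccc(N)nc3)CC2)cn1` differs from compound 2 by 1-(tert-butyl)-1H-pyrazol-4-yl in place of cyclopropyl on an aromatic carbon. The closest measured change is a 2.0-fold lower number from compound 2 to compound 3 (0.30 log units; within the scatter), where the same cyclopropyl gave way to a pyrazole bearing a methyl rather than a tert-butyl, and that step stayed within the scatter. Going by the values given here, no measured pair shows tert-butyl against methyl on the pyrazole, so nothing in these data separates compound 4 from compound 3 by more than the scatter. The step expected is a 1.3-fold lower number from compound 2 to compound 4 (0.10 log units; within the scatter), that is, none beyond the scatter. For compound 4 the estimate in this assay is 30 mL.min-1.g-1, with a range from 12 mL.min-1.g-1 to 75 mL.min-1.g-1.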

Compound 4, intrinsic clearance in microsomes: 86 mL.min-1.g-1
Beside the measured number, compound 4's estimate is 2.9-fold (0.46 log units) below it; the whole stated range lies below it.
By their numbers in this assay, from the lowest: compounds 3 and 2 (each within the scatter of the next); then compound 4. At a limit, below all of these: compound 1.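

At the position ortho to a large group, a pyrazole does not settle the outcome in this assay: the substituent on its nitrogen also counts, and tert-butyl in place of methyl on that aromatic nitrogen gives the only step shown that changes this substituent alone (a 4.5-fold higher number from compound 3 to compound 4 (0.66 log units; beyond the scatter)). Measured against cyclopropyl, the 1-(tert-butyl)-1H-pyrazol-4-yl group gives a step beyond the scatter (a 2.3-fold higher number from compound 2 to compound 4 (0.35 log units; beyond the scatter)), whereas the step from the same cyclopropyl to the 1-methyl-1H-pyrazol-4-yl group stayed within it. Against methoxy the change reads as a floor only (an at least 6.1-fold higher number from compound 1 to compound 4 (0.78 log units; beyond the scatter)), as its starting point is a limit: the limit of < 14 mL.min-1.g-1 in this assay, at which 1 of the 4 values shown sits.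

The compounds shown hold only methyl and tert-butyl on the pyrazole nitrogen, so it remains open where an ethyl, an isopropyl or a longer chain ending in a hydroxyl or an amine would fall on this read-out. They also give no reason for the rise with tert-butyl, and they do not show whether it would recur with another core or at another position.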